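The source may hold more compounds than are shown below. What is called first, only, known or untested is meant among the compounds shown, and "the series" means these compounds.

Measured so far in a functional assay on A549 cells (Homo sapiens) for cytotoxicity, read by MTT assay; a higher number here means a weaker inhibitor, a lower number a stronger inhibitor:

Compound 1, `CC(C)(C)Nc1c(C#N)c(F)c2c(N)nc(N)nc2c1Cl`: compound 1 gives 313 ug/mL.
Compound 2, `CC(C)(C)Nc1c(C#N)c(F)c2c(N)nc(N)nc2c1F`: for compound 2 the read-out is a limit, > 1000 ug/mL.
Compound 3, `CCCCNc1c(C#N)c(NCCCC)c2c(N)nc(N)nc2c1Cl`: compound 3 gives 2 ug/mL.

For the measured compounds named here, the one single-point change with a measured outcome is fluoro in place of chloro on an aromatic carbon, giving an at least 3.1-fold higher number from compound 1 to compound 2 (0.50 log units; beyond the scatter). The size of that step can only be bounded, since the value of compound 2 sits at the limit of > 1000 ug/mL in this assay, at which 1 of the 3 values shown sits. Compound 3 shares the two amino groups and the nitrile with compound 1 but differs in more than one place; how the two cores differ is not broken down here. Going by the values given here, of the two numbers known, compound 3 has the lower one, and its gap to compound 1 lies well beyond the scatter.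

Compound 4, `CCCCNc1c(C#N)c(NCCCC)c2c(N)nc(N)nc2c1F`, is not yet measured. It stands to compound 3 as compound 2 stands to compound 1: fluoro in place of chloro on an aromatic carbon. This is the same kind of change, not the same change: in compound 3 the aromatic carbon concerned is ortho to a butylamino group and para to a butylamino group, whereas in compound 1 it is ortho to a (tert-butyl)amino group and para to a fluoro group. In this assay the step from compound 3 to compound 4 is expected to be a 4.0-fold higher number from compound 3 to compound 4 (0.60 log units; beyond the scatter), resting on the same kind of change having given an at least 3.1-fold higher number from compound 1 to compound 2 (0.50 log units; beyond the scatter), with the caveat that the earlier step is known only as a lower bound. Compound 4 is accordingly estimated at 8 ug/mL, with a range of 2 ug/mL to 40 ug/mL.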

Compound 4, half-maximal inhibitory concentration: > 1000 ug/mL
Compound 4: a limit, no number; the forecaster's own chance of this, stated with the estimate: 5%; at least 120-fold (2.09 log units) between middle value and limit.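

In this assay, fluoro in place of chloro on an aromatic carbon again raises the number on the core with butylamino groups, giving an at least 500-fold higher number from compound 3 to compound 4 (2.69 log units; beyond the scatter). Compound 4 reads > 1000 ug/mL, which is a limit of the assay and not a number: the limit of > 1000 ug/mL in this assay, at which 2 of the 4 values shown sit. The direction of the change is therefore shared by the only two pairs shown, with neither going against it, but this does not establish a size that can be carried from one core to another, nor does it show whether the core alters the size of the step: the same change on two cores in this assay, an at least 3.1-fold higher number (0.50 log units; beyond the scatter) from compound 1 to compound 2 and an at least 500-fold higher number (2.69 log units; beyond the scatter) from compound 3 to compound 4; the limit leaves it open whether they differ.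

The compounds shown leave open how the two fluoro compounds would read if a number could be obtained, and how a hydrogen, a bromo group or a methoxy group would behave on the same aromatic carbon, where only chloro and fluoro appear here. They also leave open which of the differences between the chloro compounds, the butylamino or the (tert-butyl)amino group and the second butylamino group or the fluoro group, matters in this read-out, and whether a longer chain or a cyclic amine in place of butylamino would retain the low number of compound 3.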